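Swapping a formyl for hydroxymethyl on the shared core

The source may hold more compounds than are shown below. What is called first, only, known or untested is meant among the compounds shown, and "the series" means these compounds.

Measured so far in an assay on isolated protein for inhibition of Amine oxidase [flavin-containing] A (Homo sapiens), read by fluorescence and spectrophotometry, with a stated time of 20 min; a lower number here means a stronger inhibitor, a higher number a weaker inhibitor:
Compound 1 `Cc1ccc(-c2cc3cc(C#N)c(C#N)cc3n2O)cc1` gives 1140 nM.
Compound 2 `COn1c(-c2ccc(C)cc2)c(C=O)c2cc(C#N)c(C#N)cc21` gives 405 nM.
Compound 3 `COc1ccc(-c2c(C=O)c3cc(C#N)c(C#N)cc3n2OC)cc1` gives 147 nM.

Compound 2 stands in the middle of these three: compound 1 gives a higher number, and the step of a 2.8-fold lower number from compound 2 to compound 3 (0.44 log units; beyond the scatter) reaches the lowest number of the set.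

Compound 4 `COn1c(-c2ccc(C)cc2)c(CO)c2cc(C#N)c(C#N)cc21` differs from compound 2 by one change: hydroxymethyl in place of formyl on an aromatic carbon. Within the data shown here, no measured step touches this part of the core; the only measured step, a 2.8-fold lower number from compound 2 to compound 3 (0.44 log units; beyond the scatter), concerns the methoxy in place of methyl on the separate aromatic ring and so says nothing direct about the present change. Among the measured compounds shown here, with no guiding precedent, the expectation for compound 4 is a number close to that of compound 2, a step of about a 1.4-fold higher number from compound 2 to compound 4 (0.13 log units; within the scatter), not beyond the scatter. Compound 4 is therefore estimated at 550 nM, with a range from 200 nM to 1600 nM.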

Compound 4, half-maximal inhibitory concentration: 5120 nM
Beside the measured number, compound 4's estimate is 9.3-fold (0.97 log units) below it; measured number outside the range, above it.
By their numbers in this assay, from the lowest: compound 3; then compound 2; then compound 1; then compound 4.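

In this assay this position proves sensitive: hydroxymethyl in place of formyl gives a 13-fold higher number from compound 2 to compound 4 (1.10 log units; beyond the scatter), a large weakening, although both groups hold the same count of heavy atoms. Among these compounds, the only earlier step concerned the separate aromatic ring, so this is the first sign that the group on this carbon matters. Nothing measured here explains the loss. Open, on these data alone, is whether other groups on this carbon, such as a carboxylic acid or an aminomethyl group, would match formyl or fall towards hydroxymethyl.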